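This account rests on a few compounds, and the source may have more. Where it says the series, first, only, none or still open, it means among the compounds named here.

Among the compounds with values here, in a functional assay, with a stated time of 20 min, tested at 50 uM (on this read-out lower numbers stand for a weaker effect and higher numbers for a stronger effect at the one concentration tested), compound 2 `COc1cc(/C=C/C(=O)C2=C(/C=C/c3ccc(O)c(OC)c3)NC(=O)NC2c2c(Cl)cccc2Cl)ccc1O` gives 44.2%, the lowest of the two numbers measured so far. Within the data shown here, its nearest neighbour, compound 1 `COc1cc(/C=C/C(=O)C2=C(/C=C/c3ccc(O)c(OC)c3)NC(=O)NC2c2ccc(N(C)C)cc2)ccc1O`, gives 89.2%; the one step measured, a number 45 percentage points lower from compound 1 to compound 2 (beyond the scatter), shows how much the group on that saturated ring carbon can matter. Compound 3 `COc1cc(/C=C/C(=O)C2=C(/C=C/c3ccc(O)c(OC)c3)NC(=O)NC2c2cccc([N+](=O)[O-])c2)ccc1O` differs from compound 2 by 3-nitrophenyl in place of 2,6-dichlorophenyl on a saturated ring carbon. That single step bears on the change only loosely, since a different group enters here, so the direction is uncertain. Compound 3 is therefore expected to give about 62%, between 35% and 90%, an expected step of a number 17.8 percentage points higher from compound 2 to compound 3 (beyond the scatter).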

Compound 3, a percentage reported as activity, at one concentration (the size of the read-out at that concentration, not a potency): 48%
Beside the measured number, compound 3's estimate is 14 percentage points above it; the range from low to high includes it.
By their numbers in this assay, from the lowest: compounds 2 and 3 (each within the scatter of the next); then compound 1.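

In this assay, 3-nitrophenyl and 2,6-dichlorophenyl on the saturated ring carbon cannot be told apart (a number 3.8 percentage points higher from compound 2 to compound 3 (within the scatter)), although they differ in their atoms and in where the phenyl ring is substituted. Compound 3 also stands well apart from compound 1 (a number 41.2 percentage points lower from compound 1 to compound 3 (beyond the scatter)), so the 4-(dimethylamino)phenyl compound now sits alone at the high end of these three. Nothing measured here explains either result. Still open, as far as these compounds go, is whether the high number needs the dimethylamino group itself. A phenyl ring carrying a plain amino group, or an unsubstituted phenyl, would help to settle that.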